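Working notes: ether and enamide variants, cell growth inhibition

A few compounds are considered here, and "the series" means these few. Any claim that something is new, unique, unknown or untested is made for them only; others in the source may bear on it.

Measured compounds and values:
- compound 1 `O=C(O)COc1ccncc1-c1ccc2ccccc2c1`: "not determined" (no result reported)
- compound 2 `O=C(/C=C/c1ccncc1-c1ccc2ncccc2c1)N1CCOCC1`: "not determined" (no result reported)
- compound 3 `CNC(=O)/C=C/c1ccncc1-c1ccc2cc[nH]c2c1`: 10400 nM

The series is read in a functional assay on HCT-116 cells (Homo sapiens) for inhibition, read by MTT assay, with a stated time of 72 h; on this read-out higher numbers stand for weaker inhibition of growth and lower numbers for stronger inhibition of growth. Only compound 3 carries a number there. Compound 1, carrying the carboxymethoxy group, has no single value in this assay, and compound 2 is the further entry without one, so compound 1 cannot be placed against any other member on the numbers shown.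

Compound 4 `CN(C)C(=O)/C=C/c1ccncc1-c1ccc2ccccc2c1` is the next entry to be measured. It differs from compound 1 by 2-(dimethylcarbamoyl)ethenyl in place of carboxymethoxy on an aromatic carbon. Among the measured compounds shown here, no step between measured compounds exists, and with no value for compound 1 the size of the step to compound 4 in this assay cannot be taken from the data; no direction is claimed for it.

For the measured compounds named here, the only anchor is compound 3, which gives 10400 nM in this assay and also carries a 2-(carbamoyl)ethenyl-type chain rather than an ether. Going by the values given here, on that single anchor compound 4 is estimated at 8000 nM in this assay, with a broad range of 1500 nM to 40000 nM reflecting that only one number supports the expectation.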

Compound 4, concentration for 50% growth inhibition: 4540 nM
Beside the measured number, compound 4's estimate is 1.8-fold (0.25 log units) above it; measured number inside the range.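

Among the compounds shown here, no step from compound 1 to compound 4 can be read in this assay: compound 1 has no single number there, while compound 4 gives 4540 nM. The compounds shown leave open how carboxymethoxy and 2-(dimethylcarbamoyl)ethenyl compare on the shared core. Nothing at hand bears on this result.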